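Series notes: thiophen-2-yl in place of furan-2-yl

This account rests on a few compounds, and the source may have more. Where it says the series, first, only, none or still open, it means among the compounds named here.

Within the data shown here, the three measured members share one core and differ only in the aromatic group on the carbon with a double bond to nitrogen. Compound 1 `CC1=CC[C@H](C(C)(C)NC(=S)N/N=C/c2cccc(Cl)c2)CC1` gives 26900 nM in a functional assay on 786-0 cells (Homo sapiens) for inhibition, read by sulforhodamine B assay, with a stated time of 48 h; on this read-out lower numbers stand for stronger inhibition of growth and higher numbers for weaker inhibition of growth. Compound 2 `CC1=CC[C@H](C(C)(C)NC(=S)N/N=C/c2ccc(Cl)cc2)CC1` reaches (the limit of > 100000 nM in this assay, at which 1 of the 3 values shown sits), reporting > 100000 nM in this assay, which is a limit and not a number. Compound 3 `CC1=CC[C@H](C(C)(C)NC(=S)N/N=C/c2ccco2)CC1` gives 9800 nM in this assay, the lowest of the two numbers shown. The gap to the nearest number is a 2.7-fold lower number from compound 1 to compound 3 (0.44 log units; beyond the scatter); further away, an at least 10-fold lower number from compound 2 to compound 3 (1.00 log units; beyond the scatter).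

Compound 4 `CC1=CC[C@H](C(C)(C)NC(=S)N/N=C/c2cccs2)CC1` differs from compound 3 by thiophen-2-yl in place of furan-2-yl on a carbon with a double bond to nitrogen. Among the measured compounds shown here, no measured step exchanges one five-membered aromatic ring with 1 hetero atom for another; the steps seen, an at least 3.7-fold higher number from compound 1 to compound 2 (0.57 log units; beyond the scatter) and a 2.7-fold lower number from compound 1 to compound 3 (0.44 log units; beyond the scatter), concern chlorophenyl groups and bear on this change only loosely. Little movement in this assay is expected, with no firm direction. Compound 4 is therefore estimated at 8000 nM, between 3000 nM and 25000 nM. The step this implies, a 1.2-fold lower number from compound 3 to compound 4 (0.09 log units; within the scatter), is expected to stay within the scatter.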

Compound 4, concentration for total growth inhibition: 26700 nM
The estimate for compound 4 lay 3.3-fold (0.52 log units) below the measured number; measured number above the stated range.
By their numbers in this assay, from the lowest: compound 3; then compounds 4 and 1 (each within the scatter of the next). At a limit, above all of these: compound 2.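

Exchanging one five-membered aromatic ring with 1 hetero atom for another on the carbon with a double bond to nitrogen is not a silent change in this assay: the result is a 2.7-fold higher number from compound 3 to compound 4 (0.44 log units; beyond the scatter), so furan-2-yl and thiophen-2-yl are not interchangeable at this place. Thiophen-2-yl instead matches 3-chlorophenyl, with a 1.0-fold lower number from compound 1 to compound 4 (0.00 log units; within the scatter), and remains clear of 4-chlorophenyl, with an at least 3.7-fold lower number from compound 2 to compound 4 (0.57 log units; beyond the scatter), although compound 2 is a limit and not a number: the limit of > 100000 nM in this assay, at which 1 of the 4 values shown sits.

The compounds shown do not tell what separates furan-2-yl from thiophen-2-yl. Going by these compounds, it also remains open whether an amine or a carboxylic acid on the furan-2-yl ring, or a pyridine ring in its place, would keep the number of compound 3 or move it.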